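Compound 3 to compound 4: loss of trifluoromethoxy

The compounds below may be only part of what the source reports. "The series", "measured", "known", "first", "only" and "open" are said of these compounds alone.

In an ADME assay on BJ cells (Homo sapiens) for cytotoxicity, with a stated time of 72 h (a higher number here means that more compound is needed for the effect, a lower number that less compound is needed), compound 1 (`CCc1ccc(-c2nc3c(c(C)nn3-c3ccccc3)c(-c3ccccc3[N+](=O)[O-])c2C#N)cc1`) gives > 20000 nM as a limit of the assay. Compound 2 (`CCc1ccc(-c2nc3c(c(C)nn3-c3ccccc3)c(-c3ccccc3C(F)(F)F)c2C#N)cc1`) gives > 20000 nM as a limit too. Compound 3 (`CCc1ccc(-c2nc3c(c(C)nn3-c3ccccc3)c(-c3ccccc3OC(F)(F)F)c2C#N)cc1`) stands at > 20000 nM which is again a limit and not a number.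

Compound 4 (`CCc1ccc(-c2nc3c(c(C)nn3-c3ccccc3)c(-c3ccccc3)c2C#N)cc1`) carries hydrogen in place of trifluoromethoxy on an aromatic carbon.

The steps bearing on this change are a step that the two limits leave unreadable from compound 1 to compound 2 and a step that the two limits leave unreadable from compound 1 to compound 3 and a step that the two limits leave unreadable from compound 2 to compound 3 and none has a readable size. All the evidence is the limit of > 20000 nM in this assay, at which 3 of the 3 values shown sit, and it gives no direction.

In this assay the expected outcome is a number no higher from compound 3 to compound 4 (the limit leaves the size open) with nothing beyond the scatter expected. Compound 4 is estimated at 20000 nM (range 10000 nM to 40000 nM).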

Compound 4, half-maximal effective concentration in the BJ assay: > 20000 nM
Compound 4 gave a limit, no number; the forecaster's own chance of this, stated with the estimate: 85%; the middle value lies on the limit itself.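

In the BJ assay compound 4 gives > 20000 nM, again a limit and not a number. For the compounds shown here, no step among compound 1, compound 2, compound 3 and compound 4 can be read. The compounds shown leave open at what concentration any of them reaches the half-maximal effect.

In a physicochemical assay for solubility, read by spectrophotometry, in phosphate buffer, with a stated time of 18 h, at pH 7.4 (a lower number here means a less soluble compound, a higher number a more soluble compound), compound 3 gives 9900 nM and compound 4 gives 47000 nM. In the physicochemical assay this is a 4.7-fold higher number from compound 3 to compound 4 (0.68 log units; beyond the scatter).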